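This account rests on a few compounds, and the source may have more. Where it says the series, first, only, none or still open, it means among the compounds named here.

Compound 1, `Cc1cn([C@@H]2O[C@H](CO[Si](C)(C)C(C)(C)C)[C@@]3(OS(=O)(=O)C=C3NCC(=O)O)[C@H]2O[Si](C)(C)C(C)(C)C)c(=O)n(C)c1=O`, stands at the higher end of the two numbers recorded so far. In a functional assay on CCRF-CEM cells (Homo sapiens) (a higher number here means that more compound is tolerated, a lower number that less compound is tolerated), compound 1 gives 65000 nM. Among the compounds with values here, its only measured neighbour is compound 2, `COC(=O)C(=O)CNC1=CS(=O)(=O)O[C@@]12[C@@H](CO[Si](C)(C)C(C)(C)C)O[C@@H](n1cc(C)c(=O)n(C)c1=O)[C@@H]2O[Si](C)(C)C(C)(C)C`, which in this assay gives 5570 nM. Within the data shown here, the single measured step, a 12-fold lower number from compound 1 to compound 2 (1.07 log units; beyond the scatter), replaces the hydroxy on the carbonyl carbon with methoxycarbonyl and is the one piece of evidence available for changes at this position.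

The piece now follows compound 1 to compound 3, `Cc1cn([C@@H]2O[C@H](CO[Si](C)(C)C(C)(C)C)[C@@]3(OS(=O)(=O)C=C3NCC(=O)C(N)=O)[C@H]2O[Si](C)(C)C(C)(C)C)c(=O)n(C)c1=O`. The change is carbamoyl in place of hydroxy on a carbonyl carbon. As in the step to compound 2, the hydroxy on the carbonyl carbon is exchanged for a group that carries a carbonyl, so the step from compound 1 to compound 2 is the one that bears on it, and it was large. Compound 3 carries carbamoyl rather than methoxycarbonyl, so the same direction is expected but with a more cautious size. For compound 3 the expected step is a 5.4-fold lower number from compound 1 to compound 3 (0.73 log units; beyond the scatter). Compound 3 is therefore estimated at 12000 nM, with a range from 4000 nM to 40000 nM.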

Compound 3, half-maximal cytotoxic concentration: 9960 nM
Beside the measured number, compound 3's estimate is 1.2-fold (0.08 log units) above it; the range from low to high includes it.
By their numbers in this assay, from the lowest: compounds 2 and 3 (each within the scatter of the next); then compound 1.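

In this assay, carbamoyl in place of hydroxy on a carbonyl carbon gives a 6.5-fold lower number from compound 1 to compound 3 (0.81 log units; beyond the scatter), so the lower number at this position no longer rests on methoxycarbonyl alone. The two replacements also end up alike: amino in place of methoxy on a carbonyl carbon gives a 1.8-fold higher number from compound 2 to compound 3 (0.25 log units; within the scatter), which lies within the scatter, so the measurements do not separate carbamoyl from methoxycarbonyl here. Across the three compounds, replacing the hydroxy lowers the number with either of these two groups, and no compound shown goes against this.

It remains open whether the added carbonyl is needed at all, since neither a methoxy nor an amino group standing directly in place of the hydroxy appears among these compounds. On these data alone, it is equally open how a longer chain ending in a carboxylic acid, or a substituted amide such as N-methylcarbamoyl, would read in this assay. Nothing measured here offers an explanation for the size or direction of these steps.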